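The source may report more compounds than this note shows. Statements on the series, on what has been measured and on what is new or still open speak of the compounds shown alone.

Compound 1 `Cc1ccc2cc(CN(Cc3ccc(F)cc3)Cc3ccc(C(C)C)cc3)c(=O)[nH]c2c1` gives > 33000 nM in a toxicity assay on MDCK cells (Canis lupus familiaris) for cytotoxicity, read by crystal violet staining, with a stated time of 48 h (a higher number here means that more compound is tolerated, a lower number that less compound is tolerated), which is a limit of the assay and not a number.
Compound 2 `Cc1ccc2cc(CN(Cc3ccc(F)cc3)Cc3ccc(C(C)(C)C)cc3)c(=O)[nH]c2c1` gives > 33000 nM in this assay, again a limit.
Compound 3 `Cc1ccc2cc(CNCc3ccc(F)cc3)c(=O)[nH]c2c1` gives > 33000 nM in this assay, again a limit.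

Compound 2 therefore stands at the edge of what this assay can report: there is no number for it, and the two other values shown are limits as well, all three sitting at the limit of > 33000 nM in this assay, at which 3 of the 3 values shown sit. The change from compound 2 to compound 4 `Cc1ccc2cc(CN(Cc3ccc(C(C)(C)C)cc3)CC3CCCCC3)c(=O)[nH]c2c1` is cyclohexyl in place of 4-fluorophenyl on a saturated chain carbon bound to an amine nitrogen; cut one bond further out, the same difference reads 4-fluorobenzyl to cyclohexylmethyl. Three measured steps connect the compounds shown: a step that the two limits leave unreadable from compound 1 to compound 2, a step that the two limits leave unreadable from compound 1 to compound 3 and a step that the two limits leave unreadable from compound 2 to compound 3. None of them can be given a size or a direction because both ends of each sit at the limit of > 33000 nM in this assay, at which 3 of the 3 values shown sit. So the measured steps say only that changing the groups on the amine nitrogen, in the ways tried, has not brought any compound within the measurable range. The expectation for compound 4 is the same: no step beyond the scatter that could be read, and most likely another limit. The step from compound 2 to compound 4 is expected to be a step that the limit leaves unreadable from compound 2 to compound 4. Compound 4 is estimated at 40000 nM, within a range from 12000 nM to 120000 nM.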

Compound 4, half-maximal cytotoxic concentration: > 10000 nM
Compound 4 was reported as a limit; the forecaster's own chance of this, stated with the estimate: 75%; the middle value does not contradict the limit.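

In this assay compound 4 gives > 10000 nM, which is a limit and not a number. Compound 2 is also reported only as a limit, so no size or direction can be read for the change from compound 2 to compound 4. The compounds shown leave open where the half-maximal cytotoxic concentration of any of them actually lies.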